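This account rests on a few compounds, and the source may have more. Where it says the series, first, only, none or still open, it means among the compounds named here.

Measured compounds in an assay on cells with melanin-concentrating hormone receptor 1 (Homo sapiens) as the target, read by radioligand binding; a lower number here means a stronger inhibitor, a higher number a weaker inhibitor:
- compound 1, `CC1CCCC(Oc2cccc3ccc(N)nc23)C1`: 640 nM
- compound 2, `Nc1ccc2cccc(OC3CCCCCC3)c2n1`: 137 nM
- compound 3, `Nc1ccc2cccc(OC3CCCC3)c2n1`: > 2000 nM

Compound 3 gives only a limit of the assay, not a number, in this assay: > 2000 nM. That places compound 3 at the limit of > 2000 nM in this assay, at which 1 of the 3 values shown sits, the weak end of the three values shown. Compound 2 gives 137 nM and compound 1 gives 640 nM, so both carry real numbers where compound 3 carries none.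

The next compound, compound 4, `Nc1ccc2cccc(OCC3CCCO3)c2n1`, is not yet measured in this assay. It differs from compound 3 in one place: (oxolan-2-yl)methyl in place of cyclopentyl on an oxygen on an aromatic ring. The entering group is close in size to the one it replaces and brings one hydrogen-bond acceptor into the part that sits on the oxygen.

Among the measured compounds shown here, no measured step between two compounds is available, so the size of the change from compound 3 to compound 4 in this assay cannot be read from a comparable pair. The expectation is a step toward stronger binding, but a modest one, likely within or only slightly beyond the scatter, as an at least 1.3-fold lower number from compound 3 to compound 4 (0.12 log units; that floor lies within the scatter) is estimated. Compound 4 is expected to give about 1500 nM, within a range from 400 nM to 5000 nM.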

Compound 4, half-maximal inhibitory concentration: > 2000 nM
Compound 4: only a limit was reported; the forecaster's own chance of this, stated with the estimate: 40%; middle value at least 1.3-fold (0.12 log units) from the limit.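

Compound 3 and compound 4 both stand only as limits in this assay, so no step between them can be read: the limit of > 2000 nM in this assay, at which 2 of the 4 values shown sit.

The compounds shown leave open whether (oxolan-2-yl)methyl in place of cyclopentyl on an oxygen on an aromatic ring changes the read-out at all, and in which direction.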